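This account rests on a few compounds, and the source may have more. Where it says the series, first, only, none or still open, it means among the compounds named here.

Measured so far:
- compound 1, `COc1ccc2c(c1)c(C=O)cn2Cc1cn([C@@H]2O[C@H](COC(C)=O)[C@@H](OC(C)=O)[C@H](OC(C)=O)[C@H]2OC(C)=O)nn1`: 136000 nM
- compound 2, `CC(=O)OC[C@H]1O[C@@H](n2cc(Cn3cc(/C=C/C(=O)c4cccnc4)c4ccccc43)nn2)[C@H](OC(C)=O)[C@@H](OC(C)=O)[C@@H]1OC(C)=O`: 29000 nM

In a functional assay on DU-145 cells (Homo sapiens) for cytotoxicity, read by sulforhodamine B assay, with a stated time of 48 h (on this read-out higher numbers stand for weaker inhibition and lower numbers for stronger inhibition), compound 1 gives the higher of the two numbers, and compound 2 gives the lower one, a gap that is beyond the scatter, so compound 2 is the stronger inhibitor of the two.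

Compound 3, `COc1ccc2c(c1)c(/C=C1/C(=O)Nc3ccc(F)cc31)cn2Cc1cn([C@@H]2O[C@H](COC(C)=O)[C@@H](OC(C)=O)[C@H](OC(C)=O)[C@H]2OC(C)=O)nn1`, has not been measured in this assay. It differs from compound 1 in one place: a group of 12 heavy atoms (9 carbon, 1 nitrogen, 1 oxygen, 1 fluorine; one five-membered non-aromatic ring with 1 hetero atom, one six-membered aromatic ring of carbon only) in place of a group of 2 heavy atoms (1 carbon, 1 oxygen; no ring), on an aromatic carbon

For the measured compounds named here, no step between two measured compounds has this change, so the expectation rests on the two values shown. Compound 2 shows that a larger group in place of a small one at the core can come with a lower number. For compound 3 the step from compound 1 is expected to be a 9.1-fold lower number from compound 1 to compound 3 (0.96 log units; beyond the scatter), that is, toward stronger inhibition and beyond the scatter. Compound 3 is therefore estimated at 15000 nM in this assay, with a range from 3000 nM to 60000 nM.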

Compound 3, half-maximal inhibitory concentration: > 200000 nM
Compound 3: a limit, no number; the forecaster's own chance of this, stated with the estimate: 5%; middle value at least 13-fold (1.12 log units) away from the limit.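

The value of compound 3 is a limit and not a number: the limit of > 200000 nM in this assay, at which 1 of the 3 values shown sits. In this assay this gives an at least 1.4-fold higher number from compound 1 to compound 3 (0.16 log units; that floor lies within the scatter), so only a floor is known, and that floor alone does not set compound 3 clearly apart from compound 1. Even so, the change shows what the earlier compounds could not: on this aromatic carbon of the shared core, replacing formyl with a much larger group of two rings does not by itself bring a lower number.

On these data alone, how far the true figure of compound 3 lies past its limit remains unknown, as does the part played by the fluorine in the entering group. Also open, as far as these compounds go, is whether a small group in place of formyl at this position, such as an amine or a carboxylic acid, would lower the number.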